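A few compounds are considered here, and "the series" means these few. Any claim that something is new, unique, unknown or untested is made for them only; others in the source may bear on it.

In a functional assay on UACC-62 cells (Homo sapiens) for inhibition, read by sulforhodamine B assay, with a stated time of 48 h (on this read-out lower numbers stand for higher toxicity in this test and higher numbers for lower toxicity in this test), three compounds sharing the core of compound 2 `Nc1cc(N)c2nc(-c3ccccc3)c(NCc3ccc(Cl)c(Cl)c3)nc2c1` have been measured. Compound 2 gives 67600 nM, the highest of the two numbers shown. Compound 3 `COc1cc(CNc2nc3cc(N)cc(N)c3nc2-c2ccccc2)cc(OC)c1OC` gives 29500 nM, a lower number that lies beyond the usual scatter. Among the compounds with values here, compound 1 `CCOC(=O)[C@H](CCC(=O)O)NC(=O)c1ccc(CNc2nc3cc(N)cc(N)c3nc2-c2ccccc2)cc1` is reported only as a limit, < 100000 nM; this is the one value sitting at the limit of < 100000 nM in this assay, at which 1 of the 3 values shown sits. Compound 4 `COc1ccc(CNc2nc3cc(N)cc(N)c3nc2-c2ccccc2)cc1` has not yet been tested. It differs from compound 2 by 4-methoxyphenyl in place of 3,4-dichlorophenyl on a saturated chain carbon bound to a nitrogen on an aromatic ring. Within the data shown here, no measured pair differs in exactly this place, so the step can only be anticipated: a modest move toward a lower number, near the edge of the scatter, is expected, a 1.5-fold lower number from compound 2 to compound 4 (0.18 log units; within the scatter). Compound 4 is therefore estimated at 45000 nM, with a likely range from 20000 nM to 100000 nM.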

Compound 4, concentration lethal to 50% of the cells: 58900 nM
Beside the measured number, compound 4's estimate is 1.3-fold (0.12 log units) below it; the range from low to high includes it.
By their numbers in this assay, from the lowest: compounds 3, 4 and 2 (each within the scatter of the next, the first and the last beyond it).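

In this assay the change gives a 1.1-fold lower number from compound 2 to compound 4 (0.06 log units; within the scatter), the first step read at this position. It shows that 4-methoxyphenyl can stand in place of 3,4-dichlorophenyl on this saturated chain carbon with no difference beyond the scatter, although only the entering group carries a hydrogen-bond acceptor.

On these data alone, whether a phenyl ring carrying an amine, or a longer chain to the ring, would also stay within the scatter remains open. Compound 1 is reported only as a limit, so its place among the others stays open too: the limit of < 100000 nM in this assay, at which 1 of the 4 values shown sits.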